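A Nitro-to-Cyclopropylmethoxy Swap Awaiting a Number

This account rests on a few compounds, and the source may have more. Where it says the series, first, only, none or still open, it means among the compounds named here.

Of the compounds shown here, three that share a common core have been tested in a functional assay on SKHep cells (Homo sapiens) for antiproliferative activity, read by MTT assay, with a stated time of 12 h; on this read-out lower numbers stand for stronger inhibition and higher numbers for weaker inhibition. Compound 1, with structure `COc1cc(OC)c2c(=O)cc(/C=C/c3ccc([N+](=O)[O-])cc3)oc2c1`, carries a nitro group on its pendant aromatic ring, and in this assay compound 1 gives 22000 nM. Compound 2, with structure `COc1ccc2oc(/C=C/c3ccc(OC(F)(F)F)cc3)cc(=O)c2c1`, reaches only a limit of the assay, recorded for compound 2 as > 40000 nM. Compound 3, with structure `COc1cc(OC)c2c(=O)cc(/C=C/c3ccncc3)oc2c1`, likewise reaches only a limit, recorded for compound 3 as > 40000 nM. Compound 1 therefore stands as the sole entry with an actual number; the other two sit at the limit of > 40000 nM in this assay, at which 2 of the 3 values shown sit, so no ranking among the three can be drawn from them.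

Compound 4, with structure `COc1cc(OC)c2c(=O)cc(/C=C/c3ccc(OCC4CC4)cc3)oc2c1`, differs from compound 1 by the change (cyclopropylmethoxy in place of nitro on an aromatic carbon), cyclopropylmethoxy in place of nitro on an aromatic carbon. Among the compounds with values here, no measured pair in this set isolates that change, so the size of the step can only be guessed. The expected step of a 1.4-fold higher number from compound 1 to compound 4 (0.13 log units; within the scatter) is small, probably not beyond the usual scatter, with a lean toward weaker inhibition. Compound 4 is expected to give roughly 30000 nM, within a range from 10000 nM to 90000 nM.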

Compound 4, half-maximal inhibitory concentration: 22100 nM
For compound 4 the middle estimate is 1.4-fold (0.13 log units) above the measured one; low and high end bracket the measured number.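

In this assay, putting cyclopropylmethoxy in place of nitro on an aromatic carbon, para to a large group, gives a 1.0-fold higher number from compound 1 to compound 4 (0.00 log units; within the scatter). The two groups have little in common on paper: nitro has 3 heavy atoms and no ring, while cyclopropylmethoxy has 5 heavy atoms and a three-membered ring, yet the two numbers match within the usual scatter, so this position tolerates the exchange without any visible cost or gain on this read-out. Within the data shown here, this is also the first pair in the set that isolates a single change, and both of its members give real numbers rather than limits, so the comparison at this position can actually be read.

Going by these compounds, how an amine or a carboxylic acid on this aromatic carbon would read, or a longer chain in place of the cyclopropylmethoxy group, remains open, as does whether the match would hold on a different core. Nothing shown here explains why two such different groups give matching numbers.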